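The compounds below may be only part of what the source reports. "The series", "measured", "known", "first", "only" and "open" are said of these compounds alone.

Measured compounds in a toxicity assay on mitochondria from liver (Rattus norvegicus) for inhibition, tested at 100 uM, in the presence of a further agent that is not named here; a higher number here means more inhibition at the concentration tested (going by the name of the read-out), a lower number less inhibition:
Compound 1, `N#Cc1cc(C(=O)N2CS(=O)(=O)c3ccccc32)cc(C(F)(F)F)c1O`: 12%
Compound 2, `N#Cc1cc(C(=O)N2CS(=O)(=O)c3ccccc32)cc(Cl)c1O`: 20%
Compound 3, `C#Cc1cc(C(=O)N2CS(=O)(=O)c3ccccc32)cc(C#N)c1O`: 13%

Compound 1 has the lowest number of the three, but this says little: the step of a number 1 percentage points higher from compound 1 to compound 3 (within the scatter) and the step of a number 8 percentage points higher from compound 1 to compound 2 (within the scatter) both lie within the usual scatter, so the three compounds cannot be told apart on these numbers. Each of the three shares the same core and differs only in one group on the phenol ring.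

Compound 4, `COc1cc(C(=O)N2CS(=O)(=O)c3ccccc32)cc(C(F)(F)F)c1O`, has not been measured. Against compound 1 the change is methoxy in place of cyano on an aromatic carbon. Within the data shown here, none of the measured steps touches the cyano group: all three exchange the trifluoromethyl, chloro or ethynyl group, and all three stayed within the scatter, the step of a number 7 percentage points lower from compound 2 to compound 3 (within the scatter) included. Among the measured compounds shown here, there is thus no direct precedent for this change, and no sign that changes on this ring move the read-out much.

The step of a number 3 percentage points higher from compound 1 to compound 4 (within the scatter) is therefore expected to stay within the scatter. Compound 4 is estimated at 15%, with a range from 0% to 35%.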

Compound 4, a percentage reported as inhibition, at one concentration (the size of the read-out at that concentration, not a potency): 47%
The estimate for compound 4 lay 32 percentage points below the measured number, and the stated range ends below it.
By their numbers in this assay, from the lowest: compounds 1, 3 and 2 (each within the scatter of the next); then compound 4.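

In this assay, putting methoxy in place of cyano on the aromatic carbon ortho to a hydroxy group gives a number 35 percentage points higher from compound 1 to compound 4 (beyond the scatter), the only step among the compounds shown that lies beyond the scatter. The earlier steps shown here all kept the cyano group and exchanged only the group on another ring carbon, so they could not show that this position matters for the read-out: a single change here, with the rest of the structure kept, moves the number substantially. Nothing available explains why this exchange has so large an effect.

The compounds shown leave open whether the rise is specific to methoxy or whether an amine or a longer chain such as ethoxy at this position would give a similar number. As far as these compounds go, it also remains open whether methoxy would produce a similar step with chloro in place of trifluoromethyl.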